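Acetyl for hydroxy hydrogen: cytotoxicity notes on four compounds

A few compounds are considered here, and "the series" means these few. Any claim that something is new, unique, unknown or untested is made for them only; others in the source may bear on it.

Compound 1 `C=C1CC[C@@H]2[C@](C)(CO[Si](C)(C)C(C)(C)C)[C@H](O)CC[C@@]2(C)[C@@H]1C/C=C1/C(=O)OC[C@H]1O` is the reference point of the series; in a functional assay on Col2 cells (Homo sapiens) for cytotoxicity, read by sulforhodamine B assay (on this read-out higher numbers stand for an effect only at larger amounts of compound and lower numbers for an effect already at smaller amounts), compound 1 gives 17.1 uM. Compound 2 `C=C1CC[C@@H]2[C@](C)(COC(C)=O)[C@H](O)CC[C@@]2(C)[C@@H]1C/C=C1/C(=O)OC[C@H]1O` differs from compound 1 by a group of 3 heavy atoms (2 carbon, 1 oxygen; no ring) in place of a group of 7 heavy atoms (6 carbon, 1 silicon; no ring), on an oxygen on a saturated carbon; in this assay compound 2 gives 12.9 uM, so that a 1.3-fold lower number from compound 1 to compound 2 (0.12 log units; within the scatter). Compound 3 `C=C1CC[C@@H]2[C@](C)(CO[Si](C)(C)C(C)(C)C)[C@H](OC(C)=O)CC[C@@]2(C)[C@@H]1C/C=C1/C(=O)OC[C@H]1O` differs from compound 1 by acetyl in place of hydrogen on an oxygen on a saturated carbon; in this assay compound 3 gives 11.3 uM. Among these three compounds, none stands apart from the others beyond the scatter.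

Compound 4 `C=C1CC[C@@H]2[C@](C)(COC(C)=O)[C@H](O)CC[C@@]2(C)[C@@H]1C/C=C1/C(=O)OC[C@H]1OC(C)=O` has not yet been measured. It differs from compound 2 by acetyl in place of hydrogen on an oxygen on a saturated carbon, the same change that separates compound 3 from compound 1, made at a place described in the same words; the two cores differ as stated for compound 2 against compound 1. The expectation for compound 4 rests on the earlier step, a 1.5-fold lower number from compound 1 to compound 3 (0.18 log units; within the scatter), which stayed within the scatter, so a step of similar size, a 1.3-fold lower number from compound 2 to compound 4 (0.11 log units; within the scatter), is expected from compound 2 to compound 4. In this assay compound 4 is therefore estimated at 10 uM, with a range from 5 uM to 20 uM.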

Compound 4, concentration for half-maximal effect: 15.2 uM
For compound 4 the middle estimate is 1.5-fold (0.18 log units) below the measured one; measured number inside the range.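

In this assay, acetyl in place of hydrogen on an oxygen on a saturated carbon gives a 1.2-fold higher number from compound 2 to compound 4 (0.07 log units; within the scatter), and the two steps of this change compare as follows: the same change on two cores in this assay, a 1.5-fold lower number (0.18 log units; within the scatter) from compound 1 to compound 3 and a 1.2-fold higher number (0.07 log units; within the scatter) from compound 2 to compound 4, 1.8-fold (0.25 log units) apart, within the scatter of two such steps. Among the compounds shown here, the change from hydroxy to acetoxy can therefore be carried from the core of compound 1 to the core of compound 2 with no difference between the steps that stands out from the scatter, and neither step on its own goes beyond it. For the compounds shown here, this does not show that the change is without effect elsewhere, since it rests on only two pairs of compounds and one read-out, and steps within the scatter give the change no reliable direction.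

The compounds shown leave open how a longer acyl chain, such as hexanoyl, or an acyl group carrying an amine would behave on these oxygens. Also open, on these data alone, is whether any replacement for acetyl would move the number in this assay beyond the scatter.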